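Ring substitution on the sulfur-linked aryl of compound 1

The source may hold more compounds than are shown below. What is called first, only, known or untested is meant among the compounds shown, and "the series" means these compounds.

Measured compounds in a functional assay on SMMC-7721 cells (Homo sapiens) for inhibition, read by CCK-8 assay, with a stated time of 72 h, tested at 8 uM; on this read-out higher numbers stand for more inhibition of growth at the one concentration tested and lower numbers for less inhibition of growth:
- compound 1, `Cc1ccc(SCc2ccc(/C=C/C(=O)Nc3ccccc3N)cc2)cc1`, gives 22.2%
- compound 2, `Nc1ccccc1NC(=O)c1ccc(CSc2nccc(C(F)(F)F)n2)cc1`, gives 80.6%
- compound 3, `Nc1ccccc1NC(=O)/C=C/c1ccc(CSc2ccc(F)cc2)cc1`, gives 15.4%

On these numbers compound 1 stands second of three: compound 3 is within the scatter of it, while compound 2 sits well beyond the scatter on the higher side.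

Compound 4, `Cc1cc(C)cc(SCc2ccc(/C=C/C(=O)Nc3ccccc3N)cc2)c1`, differs from compound 1 by 3,5-dimethylphenyl in place of 4-methylphenyl on a sulfur.

Among the compounds with values here, one measured step bears on a substituent change on that aryl ring: a number 6.8 percentage points lower from compound 1 to compound 3 (within the scatter), which stayed within the scatter. Within the data shown here, no measured step covers a second methyl or the shift to 3,5-dimethylphenyl, and compound 2 shares neither the aryl nor the rest of the core. In this assay, therefore, no step beyond the scatter is expected in either direction.

Compound 4 is estimated at 23%, range 8% to 40%, meaning an expected step of a number 0.8 percentage points higher from compound 1 to compound 4 (within the scatter).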

Compound 4, percent growth inhibition at one concentration: 7.13%
Compound 4: middle estimate off by 15.9 percentage points, on the high side, and the stated range ends above it.
By their numbers in this assay, from the lowest: compounds 4, 3 and 1 (each within the scatter of the next, the first and the last beyond it); then compound 2.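

In this assay, the sulfur-linked aryl now shows a change beyond the scatter: 3,5-dimethylphenyl in place of 4-methylphenyl gives a number 15.1 percentage points lower from compound 1 to compound 4 (beyond the scatter). Against 4-fluorophenyl, the same group gives a number 8.3 percentage points lower from compound 3 to compound 4 (within the scatter), so compound 3 and compound 4 are not separated. Nothing available accounts for the step from compound 1 to compound 4.

Open, on these data alone, is whether the step follows from the second methyl or from where the methyls sit on the ring. Also open, as far as these compounds go, is how an amine or a methoxy group on this aryl would read out on the core of compound 1.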